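Turning one chain stereocentre of compound 2

A few compounds are considered here, and "the series" means these few. Any claim that something is new, unique, unknown or untested is made for them only; others in the source may bear on it.

In an in vitro ADME assay on microsomes from liver (Macaca fascicularis) for metabolic stability (on this read-out higher numbers stand for fast clearance and lower numbers for slow clearance), compound 2 `CC[C@@H](C)[C@@H]1C(=O)N[C@H](C2Cc3ccccc3C2)C(=O)N1[C@@H](C(=O)N1CCOCC1)c1ccc(C)nc1` gives 8 mL.min-1.g-1 and compound 1 `CC[C@H](C)[C@@H]1C(=O)N[C@H](C2Cc3ccccc3C2)C(=O)N1[C@@H](C(=O)N1CCOCC1)c1cnc(C)cc1C` gives 16 mL.min-1.g-1 and these two values lie within the usual scatter of each other. Compound 3 `CC[C@H](C)[C@@H]1C(=O)N[C@H](C2Cc3ccccc3C2)C(=O)N1[C@@H](C(=O)N1CCOCC1)c1ccc(C)nc1` is still unmeasured and differs from compound 2 only in its drawn configuration (the two compounds have the same atoms and bonds and differ only in configuration as drawn: 1 of 4 stereo elements differ; a stereocentre at a saturated chain carbon is drawn R in compound 2 and S in compound 3). Going by the values given here, no measured pair shows a change of this kind on its own, so the data give no direct guide to its size. In this assay the expected change is a 1.3-fold higher number from compound 2 to compound 3 (0.10 log units; within the scatter) and it stays within the scatter. The estimate for compound 3 is 10 mL.min-1.g-1 (expected range 5 mL.min-1.g-1 to 20 mL.min-1.g-1).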

Compound 3, intrinsic clearance in microsomes: 6 mL.min-1.g-1
Compound 3: the middle estimate sits 1.7-fold (0.22 log units) above what was measured; low and high end bracket the measured number.
By their numbers in this assay, from the lowest: compounds 3, 2 and 1 (each within the scatter of the next, the first and the last beyond it).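

In this assay, turning the chain stereocentre gives a 1.3-fold lower number from compound 2 to compound 3 (0.12 log units; within the scatter), so at this position either drawn configuration fits the read-out equally well within the scatter. The comparison is a clean one: the fact that compounds 2 and 3 differ only in the configuration as drawn. Hydrogen in place of methyl on an aromatic carbon gives a 2.7-fold lower number from compound 1 to compound 3 (0.43 log units; beyond the scatter), a modest step and the only new one beyond the scatter. Still open, on these data alone, is whether a longer chain at this stereocentre, or an amine or a carboxylic acid in place of that aromatic methyl, would shift clearance further.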